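This account rests on a few compounds, and the source may have more. Where it says the series, first, only, none or still open, it means among the compounds named here.

The series shares one core, drawn first as compound 1 `COc1ccccc1/C=c1/[nH]c(=O)/c(=C\c2ccccc2OC)[nH]c1=O`, for which a functional assay on MOLT-4 cells (Homo sapiens) for cytotoxicity, read by CCK-8 assay, with a stated time of 72 h (on this read-out lower numbers stand for stronger inhibition and higher numbers for weaker inhibition), reports "not determined" (no result reported). Compound 2 `C=CCn1c(=O)/c(=C\c2cc(F)ccc2C)[nH]c(=O)/c1=C\c1ccccc1OC` carries an allyl on the core and gives 3800 nM in this assay. Compound 3 `C=CCn1c(=O)/c(=C\c2ccc(F)c(Br)c2)[nH]c(=O)/c1=C\c1ccccc1OC` keeps that allyl and pairs a 2-methoxyphenyl with a 3-bromo-4-fluorophenyl; in this assay compound 3 gives "not active" (no number reported), so it has no single number, and compound 1 likewise stands without one. Among the compounds with values here, compound 3 therefore cannot be placed on a scale against compound 2: the two results show only that compound 2 has a measured value and compound 3 does not.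

The next step leads to compound 4 `C=CCn1c(=O)/c(=C\c2ccccc2OC)[nH]c(=O)/c1=C\c1ccccc1OC`, and the change from compound 3 is 2-methoxyphenyl in place of 3-bromo-4-fluorophenyl on a double-bonded chain carbon bound to an aromatic carbon. Within the data shown here, no measured pair in this set isolates that change, so its size in this assay is unknown; since compound 3 has no number, the direction can only be guessed from the one measured value, that of compound 2.

Compound 4 is expected to give roughly 5000 nM in this assay, with a plausible range of 1500 nM to 20000 nM, and a real chance of another result without a number.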

Compound 4, half-maximal inhibitory concentration: 13100 nM
Compound 4: the middle estimate sits 2.6-fold (0.42 log units) below what was measured; the range from low to high includes it.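

In this assay, within the data shown here, a change at this place, on a double-bonded chain carbon bound to an aromatic carbon, now has a measured size for the first time: with the allyl on the core kept, 2-methoxyphenyl in place of 5-fluoro-2-methylphenyl gives a 3.4-fold higher number from compound 2 to compound 4 (0.54 log units; beyond the scatter). Among these compounds, the step from compound 3 cannot be read, as compound 3 has no number, so the set shows only that compound 4 gives 13100 nM where the 3-bromo-4-fluorophenyl analogue yields no value, and the single readable step says nothing about any trend across aryl groups at this place. No measurement is available that would explain the step.

The compounds shown leave open how a plain phenyl, a pyridine ring or a phenyl carrying a carboxylic acid or an amine would behave at this place, since one pair cannot show whether the 5-fluoro or the 2-methyl of compound 2 matters. They also leave open what the allyl itself contributes, as compound 1 has no result, and whether a propyl or a longer chain on the core would change the values.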